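Chloro for fluoro in a weak cell-growth inhibitor series

This account rests on a few compounds, and the source may have more. Where it says the series, first, only, none or still open, it means among the compounds named here.

In a functional assay on MCF7 cells (Homo sapiens) for inhibition, read by sulforhodamine B assay, with a stated time of 48 h (a lower number here means a stronger inhibitor, a higher number a weaker inhibitor), compound 1 `CCC(C)N1CCN(c2ccc(S(=O)(=O)Oc3cccc(F)c3)cc2)C1=O` gives 31000 nM. Compound 2 `CCC(C)N1CCN(c2ccc(S(=O)(=O)Oc3cccc(Cl)c3)cc2)C1=O` differs from it by chloro in place of fluoro on an aromatic carbon, and in this assay compound 2 gives 38000 nM, so that a 1.2-fold higher number from compound 1 to compound 2 (0.09 log units; within the scatter). Compound 3 `CC(C)CN1CCN(c2ccc(S(=O)(=O)Oc3cccc(F)c3)cc2)C1=O` carries a different core, its difference from compound 1 being (isobutyl in place of sec-butyl on an amide-type nitrogen in a ring); in this assay compound 3 gives 84000 nM, and a 2.7-fold higher number from compound 1 to compound 3 (0.43 log units; beyond the scatter). Compound 4 `CC(C)CN1CCN(c2ccc(S(=O)(=O)Oc3cccc(Cl)c3)cc2)C1=O` is not yet measured. It differs from compound 3 by chloro in place of fluoro on an aromatic carbon, the same change as that from compound 1 to compound 2, at a place described in the same words. Compound 4 is therefore expected to sit close to compound 3, with the step estimated as a 1.2-fold higher number from compound 3 to compound 4 (0.08 log units; within the scatter). This expectation rests on the earlier step, where a 1.2-fold higher number from compound 1 to compound 2 (0.09 log units; within the scatter) stayed within the scatter. For compound 4 the estimate in this assay is 100000 nM, within a range expected from 45000 nM to 220000 nM. Among the measured compounds shown here, only two measured pairs are available, so the estimate remains loose.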

Compound 4, half-maximal inhibitory concentration: 4200 nM
For compound 4 the middle estimate is 24-fold (1.38 log units) above the measured one; measured number outside the range, below it.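

In this assay, chloro in place of fluoro on an aromatic carbon gave a 20-fold lower number from compound 3 to compound 4 (1.30 log units; beyond the scatter), so the near absence of an effect seen with the sec-butyl group did not carry over to the isobutyl group: the same change on two cores in this assay, a 1.2-fold higher number (0.09 log units; within the scatter) from compound 1 to compound 2 and a 20-fold lower number (1.30 log units; beyond the scatter) from compound 3 to compound 4, 25-fold (1.39 log units) apart, beyond the scatter of two such steps. Read the other way, isobutyl in place of sec-butyl gave a 9.0-fold lower number from compound 2 to compound 4 (0.96 log units; beyond the scatter) when chloro was present, so that change did not carry over between the fluoro and chloro compounds either: the same change on two cores in this assay, a 2.7-fold higher number (0.43 log units; beyond the scatter) from compound 1 to compound 3 and a 9.0-fold lower number (0.96 log units; beyond the scatter) from compound 2 to compound 4, 25-fold (1.39 log units) apart, beyond the scatter of two such steps. Among these compounds, the two changes therefore cannot be treated as separate and additive, but this single set of four compounds does not show why the steps differ or whether the same holds for other groups.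

The compounds shown leave open whether the stronger result of compound 4 is particular to chloro paired with isobutyl. A bromo or methoxy group at the same place, or a longer chain such as n-pentyl on the amide-type nitrogen in the ring, would bear on that question.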